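Inverting two ring stereocentres in the methyl ester

A few compounds are considered here, and "the series" means these few. Any claim that something is new, unique, unknown or untested is made for them only; others in the source may bear on it.

Three analogues of a peroxide acid have been measured in a functional assay on MEL28 cells (Homo sapiens) for cytotoxicity; on this read-out higher numbers stand for weaker inhibition and lower numbers for stronger inhibition. Compound 1 `C=CCC/C=C\C=C/CCCCCCCC[C@H]1CC[C@H]([C@@H]2CC[C@@H](CC(=O)O)OO2)O1` gives 0.5 ug/mL, and compound 2 `C=CCC/C=C\C=C/CCCCCCCC[C@@H]1CC[C@@H]([C@@H]2CC[C@@H](CC(=O)O)OO2)O1` gives 0.1 ug/mL; the two differ only in configuration, and a 5.0-fold lower number from compound 1 to compound 2 (0.70 log units; beyond the scatter) is the step between them. Compound 3 `C=CCC/C=C\C=C/CCCCCCCC[C@@H]1CC[C@@H]([C@@H]2CC[C@@H](CC(=O)OC)OO2)O1` gives 0.1 ug/mL in this assay, so that no change at the digits printed from compound 2 to compound 3 (within the scatter) and compound 3 stands level with compound 2, together at the lowest numbers of the three, while compound 1 sits a clear distance above it.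

Compound 4 `C=CCC/C=C\C=C/CCCCCCCC[C@H]1CC[C@H]([C@@H]2CC[C@@H](CC(=O)OC)OO2)O1` has not been measured. It differs from compound 3 as follows: the two compounds have the same atoms and bonds and differ only in configuration as drawn: 2 of 6 stereo elements differ; a stereocentre at a saturated ring carbon is drawn R in compound 3 and S in compound 4; a stereocentre at a saturated ring carbon is drawn S in compound 3 and R in compound 4. This is the mirror of the step already seen: compound 1 relates to compound 2 in the same way that compound 4 relates to compound 3, and the fact that compounds 1 and 2 differ only in the configuration as drawn is the ground for reading the pair as a stereochemical comparison alone. Since a 5.0-fold lower number from compound 1 to compound 2 (0.70 log units; beyond the scatter) and the ester change left the number untouched, the reverse of that configurational change is expected to raise the number by a comparable amount. Compound 4 is therefore expected to give 0.5 ug/mL in this assay, with a plausible range of 0.2 ug/mL to 1.2 ug/mL, so that a 5.0-fold higher number from compound 3 to compound 4 (0.70 log units; beyond the scatter) is the expected step.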

Compound 4, half-maximal inhibitory concentration: 0.5 ug/mL
Compound 4: middle estimate and measured number agree at the digits printed; the range from low to high includes it.
By their numbers in this assay, from the lowest: compounds 2 and 3 (each within the scatter of the next); then compounds 1 and 4 (each within the scatter of the next).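

Reversing the two ring stereocentres on the methyl ester gives a 5.0-fold higher number from compound 3 to compound 4 (0.70 log units; beyond the scatter), which matches in size, though opposite in direction, the step seen on the acid, a 5.0-fold lower number from compound 1 to compound 2 (0.70 log units; beyond the scatter), so the effect of configuration is no longer tied to the free acid. Methyl in place of hydrogen on an oxygen next to a carbonyl group had been seen on only one configuration, and the other now gives no change at the digits printed from compound 1 to compound 4 (within the scatter), so in this assay the ester change leaves the number in place on both cores: the same change on two cores in this assay, no change at the digits printed (within the scatter) from compound 2 to compound 3 and no change at the digits printed (within the scatter) from compound 1 to compound 4, 1.0-fold (0.00 log units) apart, within the scatter of two such steps. Among these four compounds, the separation into two levels therefore follows configuration alone, with no compound going against it: the fact that compounds 3 and 4 differ only in the configuration as drawn.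

The two ring stereocentres change together in every pair shown, so it remains open whether one of them alone carries the step or both are needed. Also open, on these data alone, is how an amide or a primary alcohol in place of the carboxylic acid, or a fully saturated chain in place of the unsaturated one, would stand in this assay.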